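The source may hold more compounds than are shown below. What is called first, only, known or untested is meant among the compounds shown, and "the series" means these compounds.

Compound 1, `Cc1cccc(/C(N)=N/NC(=S)N2CCSCC2)n1`, was tested in a functional assay on HeLa cells (Homo sapiens) for cytotoxicity, read by MTT assay, with a stated time of 72 h, tested at 3 uM (a higher number here means more inhibition of growth at the concentration tested, a lower number less inhibition of growth), where compound 1 gives 54.6%. Among the measured compounds shown here, the only other compound measured so far is compound 2, `N/C(=N\NC(=S)N1CCSCC1)c1ccccn1`, and in this assay compound 2 gives 39.7%. For the measured compounds named here, the one change between them is a number 14.9 percentage points lower from compound 1 to compound 2 (beyond the scatter). Compound 1 therefore stands highest of the two numbers, with compound 2 as its nearest neighbour.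

The next compound, compound 3, `Cc1cccc(/C(N)=N/NC(=S)N2CCCCC2)n1`, differs from compound 1 by piperidin-1-yl in place of thiomorpholin-4-yl on a thiocarbonyl carbon. Going by the values given here, no measured step touches this ring; the single step known, from a methyl to a hydrogen on an aromatic carbon, sits elsewhere on the shared core and says nothing about swapping one six-membered ring for another. Without any guide, the estimate stays close to the value of compound 1. Compound 3 is expected to give 52%, with a range from 34% to 68%. The estimated step, a number 2.6 percentage points lower from compound 1 to compound 3 (within the scatter), is expected to stay within the usual scatter.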

Compound 3, percent growth inhibition at one concentration: 68.9%
The estimate for compound 3 lay 16.9 percentage points below the measured number; measured number above the stated range.
By their numbers in this assay, from the lowest: compound 2; then compound 1; then compound 3.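

In this assay, piperidin-1-yl in place of thiomorpholin-4-yl on the thiocarbonyl carbon gives a number 14.3 percentage points higher from compound 1 to compound 3 (beyond the scatter), so this position responds to a ring change and not only the methyl site on the aromatic carbon does. Both groups are six-membered non-aromatic rings of 6 heavy atoms, and the sulfur of thiomorpholin-4-yl gives way to a carbon in piperidin-1-yl, so a single ring atom is enough to move the number beyond the scatter. Nothing measured here explains why this swap raises the number.

On these data alone, whether a morpholin-4-yl ring, with oxygen in that ring place, or an open dimethylamino group would follow piperidin-1-yl or thiomorpholin-4-yl remains unknown. As far as these compounds go, it is also open whether removing the methyl from the aromatic carbon would lower the number with piperidin-1-yl in place as it does with thiomorpholin-4-yl.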